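Para substituent on the benzyl group: methyl to chloro

The source may hold more compounds than are shown below. What is called first, only, known or untested is meant among the compounds shown, and "the series" means these compounds.

Measured compounds:
- compound 1 `O=C1/C(=C\c2ccccc2)c2c(ncn2COCc2ccccc2)CCN1Cc1ccccc1`: 9900 nM
- compound 2 `Cc1ccc(CN2CCc3ncn(COCc4ccccc4)c3/C(=C/c3ccccc3)C2=O)cc1`: 11400 nM
- compound 3 `O=C1/C(=C\c2ccccc2)c2c(ncn2COCc2ccccc2)CCN1Cc1ccc(-c2ccccc2)cc1`: 18300 nM

The three compounds share one core and differ only in the group on the benzyl ring. In a functional assay on A549 cells (Homo sapiens) for inhibition, read by MTT assay, with a stated time of 72 h (on this read-out lower numbers stand for stronger inhibition and higher numbers for weaker inhibition), compound 1 gives 9900 nM, compound 2 gives 11400 nM and compound 3 gives 18300 nM. Compound 2 stands second highest of the three numbers, but its nearest neighbour is compound 1 with a 1.2-fold higher number from compound 1 to compound 2 (0.06 log units; within the scatter) and its furthest is compound 3 with a 1.6-fold higher number from compound 2 to compound 3 (0.21 log units; within the scatter), so all three sit within the scatter of one another, and no order among them can be read from these numbers.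

Compound 4 `O=C1/C(=C\c2ccccc2)c2c(ncn2COCc2ccccc2)CCN1Cc1ccc(Cl)cc1` is the next member: chloro in place of methyl on an aromatic carbon. Among the compounds with values here, no measured step introduces chloro, so the bearing steps are those that change the same position: a 1.2-fold higher number from compound 1 to compound 2 (0.06 log units; within the scatter), a 1.8-fold higher number from compound 1 to compound 3 (0.27 log units; within the scatter) and a 1.6-fold higher number from compound 2 to compound 3 (0.21 log units; within the scatter). Each of these stays within the scatter, whether a small or a large group is put at that carbon. On that basis no step beyond the scatter is expected in this assay from compound 2 to compound 4, in either direction.

Compound 4 is therefore expected to give about 11000 nM, within 5500 nM to 22000 nM, which means an expected step of a 1.0-fold lower number from compound 2 to compound 4 (0.02 log units; within the scatter).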

Compound 4, half-maximal inhibitory concentration: 11800 nM
Beside the measured number, compound 4's estimate is 1.1-fold (0.03 log units) below it; the measured number falls inside the stated range.
By their numbers in this assay, from the lowest: compounds 1, 2, 4 and 3 (each within the scatter of the next).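

In this assay the change from 4-methylbenzyl to 4-chlorobenzyl gives a 1.0-fold higher number from compound 2 to compound 4 (0.01 log units; within the scatter) and so adds a halogen to the hydrogen, methyl and phenyl already seen on this aromatic carbon, with no step beyond the scatter. The two remaining comparisons, a 1.2-fold higher number from compound 1 to compound 4 (0.08 log units; within the scatter) and a 1.6-fold lower number from compound 3 to compound 4 (0.19 log units; within the scatter), also stay within the scatter, so this read-out separates none of the four compounds, and replacing a carbon substituent with chlorine at this place does not alter that picture. Nothing measured in this set offers an explanation for the flat result.

Going by these compounds, all four groups at this carbon carry no net charge and have no hydrogen-bond donors or acceptors, so it remains open whether an amine, a carboxylic acid or a hydroxyl group here would give a step beyond the scatter. The other carbons of this six-membered aromatic ring, and the remaining groups on the shared core, are also untested by these compounds, so the flat result cannot be extended to them.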